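Swapping a Dichlorophenyl for Indole on a Shared Core

A few compounds are considered here, and "the series" means these few. Any claim that something is new, unique, unknown or untested is made for them only; others in the source may bear on it.

Compound 2, with the structure `O=C(/C(=C\c1ccc(Cl)cc1Cl)Sc1ccc(Br)cc1)c1ccc(Br)cc1`, stands lowest of the three measured compounds in a functional assay on DU-145 cells (Homo sapiens) for inhibition, read by trypan blue exclusion, with a stated time of 96 h (on this read-out lower numbers stand for stronger inhibition of growth and higher numbers for weaker inhibition of growth), where compound 2 gives 1000 nM. Compound 3, `O=C(/C(=C\c1ccc(O)c([N+](=O)[O-])c1)Sc1ccccc1Br)c1ccc(Br)cc1`, gives 10000 nM in this assay, and compound 1, `Cc1ccsc1/C=C(/SCc1ccc(Cl)cc1)C(=O)c1ccc(Br)cc1`, gives 25000 nM; both gaps from compound 2 lie beyond the usual scatter. The untested compound 4, `O=C(/C(=C\c1c[nH]c2ccccc12)Sc1ccc(Br)cc1)c1ccc(Br)cc1`, differs from compound 2 by 1H-indol-3-yl in place of 2,4-dichlorophenyl on a double-bonded chain carbon bound to a double-bonded chain carbon. Within the data shown here, no measured pair shows this particular change, so its effect has to be estimated from the shared core alone. In this assay compound 4 is expected to give about 2000 nM, with a likely range from 500 nM to 8000 nM. The expected step of a 2.0-fold higher number from compound 2 to compound 4 (0.30 log units; within the scatter) is a slight weakening, close to the scatter of the measurement.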

Compound 4, concentration for 50% growth inhibition: 1000 nM
Estimate against measurement, compound 4: 2.0-fold (0.30 log units) above; low and high end bracket the measured number.
By their numbers in this assay, from the lowest: compounds 2 and 4 (each within the scatter of the next); then compound 3; then compound 1.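

Among these compounds, replacing 2,4-dichlorophenyl with 1H-indol-3-yl gives no change at the digits printed from compound 2 to compound 4 (within the scatter) in this assay, the first direct reading of a single change. On a double-bonded chain carbon bound to a double-bonded chain carbon, a two-ring group with a hydrogen-bond donor and no chlorine can therefore stand in for a dichlorinated single ring with no change beyond the scatter. Nothing available explains this match. Going by these compounds, whether an aminophenyl or carboxyphenyl group would fit this position equally well remains open.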